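Changing the amine on the acrylamide chain

The source may hold more compounds than are shown below. What is called first, only, known or untested is meant among the compounds shown, and "the series" means these compounds.

Among the compounds with values here, compound 2 `COc1cc2ncnc(N3CCc4ccccc43)c2cc1NC(=O)/C=C/CN1CCN(C)CC1` stands at the top of the two numbers so far: in a functional assay on PC-3 cells (Homo sapiens) for antiproliferative activity, read by MTT assay, with a stated time of 72 h (on this read-out higher numbers stand for weaker inhibition and lower numbers for stronger inhibition), compound 2 gives 9180 nM. Within the data shown here, its only neighbour, compound 1 `COc1cc2ncnc(N3CCc4ccccc43)c2cc1NC(=O)/C=C/CN1CCCC1`, gives 2620 nM in this assay, and the single measured step, a 3.5-fold higher number from compound 1 to compound 2 (0.54 log units; beyond the scatter), shows that exchanging the amine ring at this position moves the read-out by a modest, though real, amount. Compound 3 `COc1cc2ncnc(N3CCc4ccccc43)c2cc1NC(=O)/C=C/CN1CCC(CO)CC1` has not yet been measured; it differs from compound 2 by 4-(hydroxymethyl)piperidin-1-yl in place of 4-methylpiperazin-1-yl on a saturated chain carbon bound to a double-bonded chain carbon. Among the measured compounds shown here, only the step from compound 1 to compound 2 bears on this change. That step alters the same ring at the same place, and it was modest in size. Compound 3 is therefore expected to sit somewhat below compound 2 in this assay, a downward step of about a 2.0-fold lower number from compound 2 to compound 3 (0.31 log units; beyond the scatter), though whether it returns fully to the level of compound 1 is uncertain. The estimate for compound 3 is 4500 nM, with a likely range from 1500 nM to 13000 nM.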

Compound 3, half-maximal inhibitory concentration: 2650 nM
Compound 3: middle estimate off by 1.7-fold (0.23 log units), on the high side; measured number inside the range.
By their numbers in this assay, from the lowest: compounds 1 and 3 (each within the scatter of the next); then compound 2.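

In this assay, the exchange of 4-methylpiperazin-1-yl for 4-(hydroxymethyl)piperidin-1-yl gives a 3.5-fold lower number from compound 2 to compound 3 (0.54 log units; beyond the scatter), a step as large as the one seen earlier between the pyrrolidin-1-yl and 4-methylpiperazin-1-yl compounds, but now with a second, quite different amine ring on the far side of it. The comparison of the two amines that do not carry the 4-methylpiperazin-1-yl group gives a 1.0-fold higher number from compound 1 to compound 3 (0.00 log units; within the scatter), so pyrrolidin-1-yl and 4-(hydroxymethyl)piperidin-1-yl cannot be told apart here, and among these three compounds compound 2 alone stands apart, with the weakest inhibition, its steps to both others lying beyond the scatter. Nothing available here bears on why the read-out shifts with the amine at this place on the chain.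

The three compounds leave open whether the shift follows the second ring nitrogen of 4-methylpiperazin-1-yl, its methyl group, or the whole ring, and whether the hydroxymethyl group of compound 3 contributes at all. A plain piperidin-1-yl, a morpholin-4-yl or an open-chain dimethylamino group on the same saturated chain carbon would speak to these questions.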